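The source may hold more compounds than are shown below. What is called first, only, known or untested is meant among the compounds shown, and "the series" means these compounds.

Measured so far:
- compound 1, `O=C(Nc1ccc2[nH]c(=O)[nH]c2c1)[C@H]1CCCN1C(=O)C1(c2cccc(Cl)c2)CCCC1`: 0.398 nM in an assay on isolated protein for inhibition of histone acetyltransferase p300 (Homo sapiens), with a stated time of 60 min; a higher number here means a weaker inhibitor, a lower number a stronger inhibitor
- compound 2, `CNC(=O)c1cccc(CNC(=O)[C@H]2CCCN2C(=O)C2(c3ccc(Cl)cc3)CCCC2)c1`: 10 nM

Among the compounds with values here, compound 1 holds the lowest number of the two measured in this assay; compound 2, the only other measured compound, sits well above it, and the gap between the two values lies beyond the scatter. Within the data shown here, no single-change step between measured compounds is available, so the series offers no direct calibration for what follows.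

Compound 3, `CNC(=O)c1ccc(NC(=O)[C@H]2CCCN2C(=O)C2(c3cccc(Cl)c3)CCCC2)cc1`, is the next compound for this assay. Relative to compound 1 it carries a group of 10 heavy atoms (8 carbon, 1 nitrogen, 1 oxygen; one six-membered aromatic ring of carbon only) in place of a group of 10 heavy atoms (7 carbon, 2 nitrogen, 1 oxygen; one five-membered aromatic ring with 2 hetero atoms, one six-membered aromatic ring of carbon only), on an amide-type nitrogen. The group that leaves is part of what distinguishes compound 1 from compound 2, and compound 2 gives the weaker number, so the change is expected to move compound 3 toward weaker inhibition than compound 1, by a step of moderate size, beyond the scatter but not as wide as the full distance between compound 1 and compound 2. The estimated step of a 7.5-fold higher number from compound 1 to compound 3 (0.88 log units; beyond the scatter) is a loss. Compound 3 is therefore expected to give about 3 nM, with a likely range from 0.8 nM to 15 nM.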

Compound 3, half-maximal inhibitory concentration: 0.794 nM
The estimate for compound 3 lay 3.8-fold (0.58 log units) above the measured number; measured number outside the range, below it.
By their numbers in this assay, from the lowest: compounds 1 and 3 (each within the scatter of the next); then compound 2.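

In this assay, the amide-type nitrogen of the shared core accepts 4-(methylcarbamoyl)phenyl in place of the group with the five-membered aromatic ring with 2 hetero atoms, with a 2.0-fold higher number from compound 1 to compound 3 (0.30 log units; within the scatter). At this position, then, the five-membered aromatic ring and the second hydrogen-bond donor of the group in compound 1 can be given up with no change that this assay can distinguish, and a single six-membered aromatic ring of carbon only, bearing the methylcarbamoyl group, serves equally well here. Nothing available explains why the two groups read alike.

From the compounds shown here alone, the contribution of the methylcarbamoyl group itself remains open: an unsubstituted phenyl, or a carboxylic acid in its place, on the same amide-type nitrogen would test this directly. Compound 2 differs from compound 1 and from compound 3 in more than one place, so the role of the methylene link on that nitrogen and of the placement of the chlorine on the other aromatic ring also remains unresolved, and each would need a comparison that changes that one feature alone.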